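A few compounds are considered here, and "the series" means these few. Any claim that something is new, unique, unknown or untested is made for them only; others in the source may bear on it.

Measured compounds:
- compound 1, `O=C(CCCCCCc1ccccc1)N1CCCC1`: 12900 nM
- compound 2, `Cc1ccccc1CCCCCCC(=O)N1CCCC1`: 68400 nM

Compound 1 has the lowest of the two numbers recorded in an assay on HEK293 cells for inhibition of N-acylethanolamine-hydrolyzing acid amidase (Rattus norvegicus), read by LC-MS, with a stated time of 30 min; a lower number here means a stronger inhibitor, a higher number a weaker inhibitor; the nearest is compound 2, and that step, a 5.3-fold higher number from compound 1 to compound 2 (0.72 log units; beyond the scatter), exceeds the scatter. Compound 3, `Cc1cccc(CCCCCCC(=O)N2CCCC2)c1`, has not been measured. It differs from compound 1 by methyl in place of hydrogen on an aromatic carbon. Going by the values given here, only one measured step bears on this change: the step of a 5.3-fold higher number from compound 1 to compound 2 (0.72 log units; beyond the scatter), where a methyl also entered on an aromatic carbon of the same core, though at a different place. That step was modest and pointed towards a higher number. A methyl at the new place is expected to shift the number in the same direction, probably by a smaller amount, giving an expected step of a 1.9-fold higher number from compound 1 to compound 3 (0.29 log units; within the scatter). Compound 3 is therefore estimated at 25000 nM in this assay, with a range from 10000 nM to 70000 nM.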

Compound 3, half-maximal inhibitory concentration: 8300 nM
The estimate for compound 3 lay 3.0-fold (0.48 log units) above the measured number, and the stated range ends above it.
By their numbers in this assay, from the lowest: compounds 3 and 1 (each within the scatter of the next); then compound 2.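

In this assay, methyl in place of hydrogen on an aromatic carbon, meta to a large group, gives a step within the scatter (a 1.6-fold lower number from compound 1 to compound 3 (0.19 log units; within the scatter)), so no change in the number can be read at this position. Going by these compounds alone, the same replacement at the other place on the ring gave a step beyond the scatter (a 5.3-fold higher number from compound 1 to compound 2 (0.72 log units; beyond the scatter)), so the result shows what the earlier compounds could not: on this core, the outcome of adding this methyl differs with its place on the ring. No evidence here accounts for that difference.

Going by these compounds, whether methoxy, chlorine, an amine or a carboxylic acid at this position would also leave the number within the scatter remains open. So does the effect of a shorter or longer chain leading to the carbonyl.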